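The source may report more compounds than this note shows. Statements on the series, on what has been measured and on what is new or still open speak of the compounds shown alone.

Compound 1 `COc1cccc(COC(=O)c2cccc(S)n2)c1` is one of three compounds assessed in an assay on isolated protein for inhibition of matrix metalloproteinase-9 (Homo sapiens) (a lower number here means a stronger inhibitor, a higher number a weaker inhibitor), where compound 1 gives 93000 nM. That is the second highest of the three numbers, yet both neighbours lie within the scatter of it: compound 2 `O=C(Oc1cccc2ccccc12)c1cccc(=O)[nH]1` gives 109000 nM and compound 3 `O=C(OCc1ccc(Cl)cc1)c1cccc(=O)[nH]1` gives 68000 nM, so no order among the three can be read from these figures. Compound 4 `O=C(OCc1cccc(Oc2ccccc2)c1)c1cccc(S)n1` differs from compound 1 in a single place: phenyl in place of methyl on an oxygen on an aromatic ring. Among the measured compounds shown here, no pair of measured compounds shows what this change does, so the expected step reads a 1.2-fold lower number from compound 1 to compound 4 (0.09 log units; within the scatter), a movement not beyond the scatter in either direction. On that basis compound 4 is estimated at 75000 nM, with a range from 20000 nM to 300000 nM.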

Compound 4, half-maximal inhibitory concentration: 75000 nM
Compound 4: middle estimate and measured number agree at the digits printed, and the stated range covers the measured number.
By their numbers in this assay, from the lowest: compounds 3, 4, 1 and 2 (each within the scatter of the next).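

In this assay, among the compounds shown here, methoxy to phenoxy gives a 1.2-fold lower number from compound 1 to compound 4 (0.09 log units; within the scatter), the first single-place step in this set. At this place, on an oxygen on an aromatic ring, the added six-membered aromatic ring therefore leaves the number within the scatter, and this one step shows no gain or loss from the larger group. Nothing given here offers a reason for this result. Going by these compounds, it remains open whether an amine or a carboxylic acid in place of methoxy would move the number beyond the scatter. On these data alone, it is also open whether phenoxy would give a similar step on another core.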